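Changing the aryl group of an amide-linked aminoquinoline ether

The source may hold more compounds than are shown below. What is called first, only, known or untested is meant among the compounds shown, and "the series" means these compounds.

Compound 1, `CC(CNCC1CCCC1)Oc1cccc2ccc(N)nc12`: 100 nM
Compound 2, `CC(CNC1CCCC1)Oc1cccc2ccc(N)nc12`: 30 nM
Compound 3, `CC(C)c1ccc(C(=O)NCCCOc2cccc3ccc(N)nc23)cc1`: 60 nM

In an assay on cells with melanin-concentrating hormone receptor 1 (Homo sapiens) as the target, read by radioligand binding (a lower number here means a stronger inhibitor, a higher number a weaker inhibitor), compound 3 gives 60 nM. This sits within the usual scatter of both compound 1 and compound 2, so no order among the three can be read from these numbers. The one step shown, a 3.3-fold lower number from compound 1 to compound 2 (0.52 log units; beyond the scatter), concerns a change on an amine nitrogen and is of modest size.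

Compound 4, `N#Cc1cccc(C(=O)NCCCOc2cccc3ccc(N)nc23)c1`, is not yet measured. It differs from compound 3 by 3-cyanophenyl in place of 4-isopropylphenyl on a carbonyl carbon. Going by the values given here, no measured pair changes this part of the molecule, so the step from compound 1 to compound 2 gives only a sense of scale, not of direction. A step of modest size, possibly beyond the scatter, is therefore expected, with the direction uncertain. Compound 4 is expected to give 150 nM, with a range from 40 nM to 600 nM. The expected step is a 2.5-fold higher number from compound 3 to compound 4 (0.40 log units; beyond the scatter).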

Compound 4, half-maximal inhibitory concentration: 3 nM
Compound 4: middle estimate off by 50-fold (1.70 log units), on the high side; the whole stated range lies above it.
By their numbers in this assay, from the lowest: compound 4; then compounds 2, 3 and 1 (each within the scatter of the next, the first and the last beyond it).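

In this assay, the aryl group on the carbonyl carbon proves to be a sensitive place: 3-cyanophenyl in place of 4-isopropylphenyl gives a 20-fold lower number from compound 3 to compound 4 (1.30 log units; beyond the scatter), a large step and the only one shown at this position. The earlier step on an amine nitrogen, a 3.3-fold lower number from compound 1 to compound 2 (0.52 log units; beyond the scatter), was modest by comparison, so the aryl group of the amide can shift the number much further than that change did. Nothing measured here explains why this swap has such an effect.

The step changes both the group on the ring and where it sits, so the contribution of each cannot be separated. A plain phenyl, or a methoxy or chloro group on the ring, would be needed to show whether the nitrile itself matters.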